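The compounds below may be only part of what the source reports. "The series", "measured", "known", "first", "only" and "open" are said of these compounds alone.

In a functional assay on BXPC-3 cells (Homo sapiens) for inhibition, read by MTT assay, with a stated time of 7 days (on this read-out higher numbers stand for weaker inhibition and lower numbers for stronger inhibition), compound 1 (`O=C([C@@H]1CCCN(S(=O)(=O)c2ccc(S(=O)(=O)N3CC[C@@H](O)C3)cc2)C1)N1CCC(F)(F)CC1`) gives 330 nM, while compound 2 (`CCN(CC)S(=O)(=O)c1ccc(S(=O)(=O)N2CCC[C@@H](C(=O)N3CCC(O)CC3)C2)cc1`) gives 4710 nM. Compound 2 therefore holds the higher of the two numbers, meaning the weaker inhibition, and its gap to compound 1 lies beyond the usual scatter. These two compounds differ in more than one place, so their gap cannot be assigned to any single change. Compound 3 (`CCN(CC)S(=O)(=O)c1ccc(S(=O)(=O)N2CCC[C@@H](C(=O)N[C@H]3CCOC3)C2)cc1`) departs from compound 2 in one place, with (oxolan-3-yl)amino in place of 4-hydroxypiperidin-1-yl on a carbonyl carbon. For the measured compounds named here, no measured pair shows the effect of this exchange, so no clear direction can be argued from the data. The estimated step of a 1.2-fold lower number from compound 2 to compound 3 (0.07 log units; within the scatter) is expected to stay within the scatter. For compound 3 the expected value is 4000 nM, with an estimated range of 1300 nM to 12000 nM.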

Compound 3, half-maximal inhibitory concentration: 5270 nM
The estimate for compound 3 lay 1.3-fold (0.12 log units) below the measured number; the range from low to high includes it.
By their numbers in this assay, from the lowest: compound 1; then compounds 2 and 3 (each within the scatter of the next).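

In this assay, (oxolan-3-yl)amino in place of 4-hydroxypiperidin-1-yl on a carbonyl carbon gives a 1.1-fold higher number from compound 2 to compound 3 (0.05 log units; within the scatter) and so stays within the scatter. For the compounds shown here, this is the first comparison here that changes one place only, and it shows that, on this read-out, the six-membered ring of the leaving group can give way to a five-membered ring with a defined stereocentre without a change beyond the scatter. Nothing measured on these compounds gives a reason for this result.

As far as these compounds go, the steps from compound 1 to compound 2 and to compound 3 cannot be read, as those compounds differ in more than one place, so what part this position plays in the gap to compound 1 stays open. Also open, from the compounds shown here alone, is how the number would respond on this carbonyl carbon to a morpholin-4-yl group, or to a chain ending in a carboxylic acid.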